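Substance-P receptor series: chloro to tert-butyl on the aryl ring

The source may hold more compounds than are shown below. What is called first, only, known or untested is meant among the compounds shown, and "the series" means these compounds.

Measured compounds:
Compound 1 `Oc1n[nH]c(CN[C@H](COCc2cc(C(F)(F)F)cc(C(F)(F)F)c2)c2ccccc2)n1` gives 2.4 nM in an assay on CHO cells for displacement of a labelled ligand from Substance-P receptor (Homo sapiens); a lower number here means a stronger inhibitor, a higher number a weaker inhibitor.
Compound 2 `CCN(Cc1n[nH]c(O)n1)[C@H](COCc1cc(C(F)(F)F)cc(C(F)(F)F)c1)c1ccccc1` gives 0.8 nM in this assay.
Compound 3 `Cc1cc(Cl)cc(COC[C@H](c2ccccc2)N(C)Cc2n[nH]c(O)n2)c1` gives 2.2 nM in this assay.

Compound 3 sits second highest of the three numbers in this assay; its number and that of compound 1 lie within the scatter of each other, while compound 2 stands clearly lower. Going by the values given here, the only single-point step measured so far is a 3.0-fold lower number from compound 1 to compound 2 (0.48 log units; beyond the scatter), a change on the amine nitrogen, not on the aryl ring.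

Compound 4 `Cc1cc(COC[C@H](c2ccccc2)N(C)Cc2n[nH]c(O)n2)cc(C(C)(C)C)c1` differs from compound 3 by tert-butyl in place of chloro on an aromatic carbon. Among the compounds with values here, no measured pair changes this aryl substituent, so the step from compound 1 to compound 2 does not bear on it and nothing in the data sets its direction. Given that, compound 4 is expected to remain close to compound 3, with a 1.4-fold higher number from compound 3 to compound 4 (0.13 log units; within the scatter) estimated to stay within or near the scatter. The estimate for compound 4 in this assay is 3 nM, with a range from 1 nM to 10 nM.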

Compound 4, half-maximal inhibitory concentration: 0.42 nM
The estimate for compound 4 lay 7.1-fold (0.85 log units) above the measured number, outside the stated range (below it).
By their numbers in this assay, from the lowest: compounds 4 and 2 (each within the scatter of the next); then compounds 3 and 1 (each within the scatter of the next).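

In this assay, going by these compounds alone, this aromatic carbon turns out to be a position where the aryl substituent matters: a 5.2-fold lower number from compound 3 to compound 4 (0.72 log units; beyond the scatter), and this is the first measured change on this ring. The step lies beyond the scatter and shows that tert-butyl, with four heavy atoms, is accepted here in place of the single chlorine atom, with the methyl group and the rest of the core unchanged. Nothing measured on these compounds accounts for the step.

The compounds shown leave open how isopropyl or methoxy on this aromatic carbon would compare with chloro and tert-butyl, so a single pair supports no trend across substituents. They also leave open whether the step carries over when the methyl on the amine nitrogen gives way to an ethyl or a longer propyl chain.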